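The compounds below may be only part of what the source reports. "The series", "measured", "known", "first", "only" and "open" are said of these compounds alone.

Of the compounds shown here, three of a shared core have been measured so far. Compound 1 `O=C(O)Cc1sc(C(c2ccc(F)cc2)c2ccc(F)cc2)nc1-c1ccoc1` and compound 3 `COc1ccc(C(c2ccccc2)c2nc(-c3ccc(Cl)cc3)c(CC(=O)O)s2)cc1` are level at the digits reported in an in vitro functional assay on HEK285-7 cells for antagonist activity at prostaglandin D2 receptor 2 (Homo sapiens), read by BRET and beta-arrestin recruitment (on this read-out lower numbers stand for smaller maximal responses and higher numbers for larger maximal responses), where compound 1 gives 80% and compound 3 gives 80%; the two together stand highest of the three numbers, and their difference lies within the scatter. Compound 2 `O=C(O)Cc1sc(C2COc3ccccc3O2)nc1-c1ccc(Cl)cc1` is the furthest from compound 1. In this assay compound 2 gives 50%, a number lower than that of compound 1 and beyond the scatter.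

Compound 4 `O=C(O)Cc1sc(C(c2ccc(F)cc2)c2ccc(F)cc2)nc1-c1ccc(Cl)cc1` has not yet been measured. It departs from compound 1 in one place: 4-chlorophenyl in place of furan-3-yl on an aromatic carbon. Among the measured compounds shown here, no step between two measured compounds that differ only in this way is available, so the expectation rests on what the three values show. Compound 3, which also bears a 4-chlorophenyl group, reaches the same maximal response as compound 1, whereas compound 2, which bears a 4-chlorophenyl group as well but a different large group, falls well below. On this basis a small step or none beyond the scatter is expected, and the step of a number 2 percentage points lower from compound 1 to compound 4 (within the scatter) is the estimate of that change. Compound 4 is therefore expected to give 78% in this assay, with a range from 65% to 90%.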

Compound 4, largest response reached (reported as efficacy), in percent of the reference or control that the assay uses: 80%
Compound 4: middle estimate off by 2 percentage points, on the low side; low and high end bracket the measured number.
By their numbers in this assay, from the lowest: compound 2; then compounds 1, 3 and 4 (each within the scatter of the next).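

In this assay, among the compounds shown here, 4-chlorophenyl in place of furan-3-yl on this aromatic carbon, next to the ring nitrogen, gives no change at the digits printed from compound 1 to compound 4 (within the scatter), the first reading of this position with the rest of the molecule held fixed. For this pair, a six-membered aromatic ring of carbon only that carries a chlorine stands in for a five-membered aromatic ring with an oxygen, with the maximal response unchanged within the scatter. The pair also brings out a new comparison, since compound 4 shares the 4-chlorophenyl group with compound 2 and differs from it only in the large group, and compound 4 gives 80% where compound 2 gives 50%; no measured property here accounts for either result.

The compounds shown leave open whether this position would respond the same way to a group of another kind, such as an aminomethyl group, a carboxylic acid or a small methyl group. They also leave open whether the same exchange would read the same beside a different large group, as a single pair speaks only for the large group of compound 1.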